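The source may hold more compounds than are shown below. What is called first, only, known or untested is meant among the compounds shown, and "the series" means these compounds.

Measured compounds in a functional assay for inhibition, with Homo sapiens as the target; on this read-out higher numbers stand for weaker inhibition and lower numbers for stronger inhibition:

compound 1 `CCCc1cnc(Nc2cc[nH]n2)n2c(C)ncc12`: > 48000 nM
compound 2 `CCCc1nnc(O)n2c(C)ncc12`: > 48000 nM
compound 3 `C=CCn1ncc2c(C)nc(Cc3ccccc3)n2c1=O`: > 48000 nM

Compound 2 stands nowhere that can be ranked: its value is a limit of this assay, not a number. The same is true of compound 1 and of compound 3. Among the compounds with values here, all three sit at the limit of > 48000 nM in this assay, at which 3 of the 3 values shown sit, so no step between measured compounds can be computed, and nothing in these data separates one compound from another.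

The step to follow leads from compound 2 to compound 4 `Cc1ncc2cnnc(O)n12`. The change is hydrogen in place of propyl on an aromatic carbon. With every measured value a limit, there is no evidence that this change moves the read-out in either direction, and no step beyond the usual scatter is expected in this assay. Compound 4 is therefore expected to report only a limit as well. The estimate for compound 4 in this assay is 70000 nM, with a range from 20000 nM to 250000 nM. The estimated step that the limit leaves unreadable from compound 2 to compound 4 is expected to amount to nothing that the assay resolves.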

Compound 4, half-maximal inhibitory concentration: > 48000 nM
Compound 4 was reported as a limit; the forecaster's own chance of this, stated with the estimate: 85%; the middle value lies beyond the limit too.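

In this assay compound 4 gives > 48000 nM, a limit and not a number. Within the data shown here, no step from compound 2 to compound 4 can be read, because both stand at the same limit: the limit of > 48000 nM in this assay, at which 4 of the 4 values shown sit. The compounds shown leave open whether propyl or hydrogen at this place affects inhibition at all.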